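Working notes: a methyl added to the chain of compound 3

A few compounds are considered here, and "the series" means these few. Any claim that something is new, unique, unknown or untested is made for them only; others in the source may bear on it.

Compound 1 `COc1cc(/C=N/NC(=O)c2cc3cc([N+](=O)[O-])ccc3o2)ccc1OCc1ccc([N+](=O)[O-])cc1` gives > 80000 nM as a limit of the assay
Compound 2 `CCC(C)Oc1ccc(/N=N/C(=O)c2cc3cc([N+](=O)[O-])ccc3o2)cc1Br` gives 36000 nM
Compound 3 `O=C(COc1ccc([N+](=O)[O-])cc1)N/N=C/c1ccccc1OC(=O)c1sc2ccccc2c1Cl` gives 40000 nM

These values come from an ADME assay on Huh-7 cells (Homo sapiens) for cytotoxicity, read by a luciferase reporter, with a stated time of 72 h (on this read-out higher numbers stand for lower toxicity in this test and lower numbers for higher toxicity in this test), and compound 1 stands there only as a limit. Compound 3 (40000 nM) lies within the scatter of compound 2 (36000 nM).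

Compound 4 (`CC(Oc1ccc([N+](=O)[O-])cc1)C(=O)N/N=C/c1ccccc1OC(=O)c1sc2ccccc2c1Cl`) differs from compound 3 in one place (methyl in place of hydrogen on a saturated chain carbon bound to a carbonyl carbon and an oxygen on an aromatic ring): methyl in place of hydrogen on a saturated chain carbon bound to a carbonyl carbon and an oxygen on an aromatic ring. Among the compounds with values here, no measured pair carries this change, so the estimate is anchored on compound 3 (40000 nM). No step beyond the scatter is expected in this assay, and the expected step (a 1.1-fold lower number from compound 3 to compound 4 (0.05 log units; within the scatter)) stays within it. For compound 4 the estimated value is 36000 nM (expected range 15000 nM to 80000 nM).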

Compound 4, half-maximal cytotoxic concentration: 19000 nM
Compound 4: middle estimate off by 1.9-fold (0.28 log units), on the high side; the measured number falls inside the stated range.
By their numbers in this assay, from the lowest: compounds 4, 2 and 3 (each within the scatter of the next, the first and the last beyond it). At a limit, above all of these: compound 1.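

In this assay the methyl on the saturated chain carbon bound to a carbonyl carbon and an oxygen on an aromatic ring brings a 2.1-fold lower number from compound 3 to compound 4 (0.32 log units; beyond the scatter) and thus a modest shift towards higher toxicity in this test. Within the data shown here, this is the first single-place step, and it shows that this position responds to even one added carbon. No measured property bears on the origin of this step.

As far as these compounds go, whether a longer chain, an amine or a carboxylic acid at this carbon would shift the number further remains open. Also open, from the compounds shown here alone, is whether the methyl gives a similar step on another core.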